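This account rests on a few compounds, and the source may have more. Where it says the series, first, only, none or still open, it means among the compounds named here.

Measured compounds:
compound 1 `Brc1cccc(/N=N/N2CCCCC2)c1`, > 100000 nM
compound 2 `FC(F)(F)c1cccc(N(C[C@@H]2CCCN3CCCC[C@H]23)/N=N/c2ccccc2)c1`, 17000 nM

Both measured compounds were tested in an ADME assay on MT4 cells (Homo sapiens) for cytotoxicity, read by MTT assay, with a stated time of 96 h; a lower number here means that less compound is tolerated, a higher number that more compound is tolerated. Compound 1 is reported only as a limit of that assay, > 100000 nM, so no number is known for it. In this assay compound 2 gives 17000 nM. What is known of compound 1 is therefore the limit of > 100000 nM in this assay, at which 1 of the 2 values shown sits: it stands at the limit, while compound 2 is the only one of the two with a measured number.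

Compound 3 `c1ccc(/N=N/N2CCCCC2)cc1` has not yet been measured in this assay. It differs from compound 1 in one place: hydrogen in place of bromo on an aromatic carbon. Going by the values given here, no step between two measured compounds is known here, so the size of this change in this assay can only be expected. Compound 3 is expected to show no step beyond the scatter, a step that the limit leaves unreadable from compound 1 to compound 3. In this assay compound 3 is estimated at 150000 nM, in the range 60000 nM to 400000 nM, and it may well again be reported only as a limit.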

Compound 3, half-maximal cytotoxic concentration: > 100000 nM
Compound 3 ended at the assay's limit; the forecaster's own chance of this, stated with the estimate: 75%; the middle value does not contradict the limit.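

In this assay compound 1 and compound 3 both stand only at a limit, so no step can be read between them for hydrogen in place of bromo on an aromatic carbon. The compounds shown leave open whether this change makes any difference.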